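Methyl on a Ring Oxygen: Same Change, Second Core

The source may report more compounds than this note shows. Statements on the series, on what has been measured and on what is new or still open speak of the compounds shown alone.

Compound 1 `COc1cc(/C=N/NC(=O)OCc2ccccc2)cc(OC)c1O`: 38%
Compound 2 `COc1cc(/C=N/Nc2nc3ccccc3s2)cc(OC)c1O`: 36%
Compound 3 `COc1cc(/C=N/NC(=O)OCc2ccccc2)cc(OC)c1OC`: 95%

Of the compounds shown here, three have been tested in a physicochemical assay on cells (Homo sapiens), with a stated time of 18 h, tested at 1 uM; on this read-out lower numbers stand for a stronger effect and higher numbers for a weaker effect at the one concentration tested. Compound 1 gives 38% and compound 3 gives 95% in this assay. The two differ in one place, (methyl in place of hydrogen on an oxygen on an aromatic ring), and that change made the step of a number 57 percentage points higher from compound 1 to compound 3 (beyond the scatter), a clear weakening of the effect.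

Compound 2 shares this pattern of substituents but sits on a different core; the difference between the two cores is not broken down here. In this assay compound 2 gives 36%, a number within the scatter of compound 1.

Compound 4 `COc1cc(/C=N/Nc2nc3ccccc3s2)cc(OC)c1OC` is the untested partner of compound 2, carrying the same change, (methyl in place of hydrogen on an oxygen on an aromatic ring), that turned compound 1 into compound 3. Because the step of a number 57 percentage points higher from compound 1 to compound 3 (beyond the scatter) was large and compound 2 starts where compound 1 did, a step of similar size is expected, a number 54 percentage points higher from compound 2 to compound 4 (beyond the scatter). Within the data shown here, compound 4 is therefore estimated at 90% in this assay, between 70% and 102%, with the caveat that only one such pair has been measured.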

Compound 4, a percentage reported as activity, at one concentration (the size of the read-out at that concentration, not a potency): 100%
Beside the measured number, compound 4's estimate is 10 percentage points below it, within the range that was stated.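

In this assay, the change from hydroxy to methoxy gives a number 64 percentage points higher from compound 2 to compound 4 (beyond the scatter) and, on the other core, a number 57 percentage points higher from compound 1 to compound 3 (beyond the scatter) in the same direction, so the weakening carried over from one core to the other in both measured pairs. Among these compounds, this is still only two pairs on two cores: it shows that the change behaved alike here, but it gives no rule for any core outside these four compounds. Nothing measured here speaks to the reason for the weakening.

The compounds shown leave open what a larger group on that oxygen would do, such as an ethyl group or a longer chain in place of the methyl, and whether an amine could stand in place of the hydroxy without the same loss. They also leave open whether a third core, for example one carrying a carboxylic acid, would follow the same course.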